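Sulfonyl Aryl Variation in a Chemokine Receptor Binding Series

This account rests on a few compounds, and the source may have more. Where it says the series, first, only, none or still open, it means among the compounds named here.

Three compounds have been measured in an assay on MDA-MB-231 cells for binding affinity to C-X-C chemokine receptor type 4 (Homo sapiens), read by fluorescence and microscopy, with stated times of 10 min and 30 min; on this read-out lower numbers stand for an effect already at smaller amounts and higher numbers for an effect only at larger amounts of compound:
Compound 1 `CCN(CC)Cc1ccc(S(=O)(=O)NCc2ccc(CNC(=O)c3ccc(F)cc3)cc2)cc1` gives 1 nM.
Compound 2 `O=C(NCc1ccc(CNS(=O)(=O)c2ccc(-c3ccc(F)cc3)cc2)cc1)c1ccc(F)cc1` gives 100 nM.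
Compound 3 `O=C(NCc1ccc(CNS(=O)(=O)c2ccccc2Cl)cc1)c1ccc(F)cc1` gives 1000 nM.

Compound 3 has the highest number of the three; compound 2 stands nearest and compound 1 furthest, both beyond the scatter. Compound 4 `O=C(NCc1ccc(CNS(=O)(=O)c2ccc(F)c(F)c2)cc1)c1ccc(F)cc1` differs from compound 3 by 3,4-difluorophenyl in place of 2-chlorophenyl on a sulfonyl sulfur. Among the measured compounds shown here, the only measured step, a 100-fold higher number from compound 1 to compound 2 (2.00 log units; beyond the scatter), alters the group on the aromatic carbon, not the aryl on the sulfonyl sulfur, so it does not bear directly on this change. Compound 2 and compound 3 both vary that aryl, but no step between them is shown, and their values alone do not indicate a direction for a third aryl. No change beyond the scatter is therefore expected, no change at the digits printed from compound 3 to compound 4 (within the scatter). Compound 4 is estimated at 1000 nM, within 200 nM to 5000 nM.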

Compound 4, effective concentration (reported as EC, without a stated level of effect): 10 nM
Compound 4: the middle estimate sits 100-fold (2.00 log units) above what was measured; the whole stated range lies above it.
By their numbers in this assay, from the lowest: compound 1; then compound 4; then compound 2; then compound 3.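

The aryl on the sulfonyl sulfur proves to be a place where the read-out responds strongly: in this assay, 3,4-difluorophenyl in place of 2-chlorophenyl gives a 100-fold lower number from compound 3 to compound 4 (2.00 log units; beyond the scatter), the first step measured at this position. The two groups match in hydrogen-bond donors, acceptors and net charge, so a large step here comes without any change in those counts. Nothing at hand gives a reason for the size of this step.

Which of the two fluorines matters, if either does, remains open. So does how 3,4-dichlorophenyl or 4-fluorophenyl on the sulfonyl sulfur would read.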